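A quinoxaline in place of a quinoline

The source may hold more compounds than are shown below. What is called first, only, known or untested is meant among the compounds shown, and "the series" means these compounds.

Compound 2 `CC(C)(C)c1ccc(-c2nc3c(N4CCN(Cc5ccc6ncccc6c5)CC4)cccc3[nH]2)cc1` has the higher of the two numbers measured in a functional assay on cells (Pituitary gland cell) for antagonist activity at Gonadotropin-releasing hormone receptor (Rattus norvegicus); on this read-out lower numbers stand for stronger inhibition and higher numbers for weaker inhibition: compound 2 gives 830 nM. Compound 1 `Cn1c(=O)c(=O)[nH]c2ccc(CN3CCN(c4cccc5[nH]c(-c6ccc(C(C)(C)C)cc6)nc45)CC3)cc21` gives 44 nM in this assay, a lower number that lies beyond the scatter. Compound 3 `CC(C)(C)c1ccc(-c2nc3c(N4CCN(Cc5cccc6nccnc56)CC4)cccc3[nH]2)cc1` differs from compound 2 in one place: quinoxalin-5-yl in place of quinolin-6-yl on a saturated chain carbon bound to an amine nitrogen in a ring. Within the data shown here, no measured pair shows this change, so its effect is open. The step of a 1.7-fold lower number from compound 2 to compound 3 (0.22 log units; within the scatter) is expected to be small, if anything toward a lower number. Compound 3 is therefore estimated at 500 nM, within a range from 100 nM to 2500 nM.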

Compound 3, half-maximal inhibitory concentration: 5900 nM
Estimate against measurement, compound 3: 12-fold (1.07 log units) below; the whole stated range lies below it.
By their numbers in this assay, from the lowest: compound 1; then compound 2; then compound 3.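

In this assay, this position on a saturated chain carbon bound to an amine nitrogen in a ring does not tolerate every closely related group: quinoxalin-5-yl in place of quinolin-6-yl gives a 7.1-fold higher number from compound 2 to compound 3 (0.85 log units; beyond the scatter) even though the heavy-atom count stays the same. The change replaces one ring carbon with nitrogen and also alters the point of attachment, so this single step cannot separate the two. Quinolin-5-yl and quinoxalin-6-yl at this position would be needed to tell them apart, and the compounds shown include neither. The data shown give no cause for the step.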